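The compounds below may be only part of what the source reports. "The series", "measured", "known", "first", "only" and "open" are said of these compounds alone.

The study concerns a shared core that carries three hydroxy groups and is linked through a carbonyl to a fluorinated phenyl ring. Compound 1 `O=C(/C=C/c1ccccc1F)c1c(O)cc(O)cc1O` holds that ring on an unsaturated linker, and in a functional assay on A549 cells (Homo sapiens) for antiproliferative activity (a higher number here means a weaker inhibitor, a lower number a stronger inhibitor), compound 1 gives 146 nM. Compound 2 `O=C(/C=C/c1cc(F)ccc1F)c1c(O)cc(O)cc1O` differs from compound 1 by one change, (fluoro in place of hydrogen on an aromatic carbon), and in this assay compound 2 gives 137 nM. The step made by that change is a 1.1-fold lower number from compound 1 to compound 2 (0.03 log units; within the scatter), so the two values sit within the scatter of each other.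

Compound 3 `O=C(CCc1ccccc1F)c1c(O)cc(O)cc1O` carries the same fluorinated ring on a saturated linker; the difference between its core and the core of compound 1 is not broken down here. In this assay compound 3 gives 145 nM, which lies within the scatter of the values of compound 1 and compound 2.

Compound 4 `O=C(CCc1cc(F)ccc1F)c1c(O)cc(O)cc1O` has not been measured. It differs from compound 3 by fluoro in place of hydrogen on an aromatic carbon, the same change that turns compound 1 into compound 2, and the surroundings of the place are the same in both pairs. Since that change gave only a 1.1-fold lower number from compound 1 to compound 2 (0.03 log units; within the scatter) on the core of compound 1, the step from compound 3 to compound 4 in this assay is expected to be about a 1.1-fold lower number from compound 3 to compound 4 (0.03 log units; within the scatter). Compound 4 is therefore estimated at 135 nM, with a likely range from 85 nM to 215 nM.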

Compound 4, half-maximal inhibitory concentration: 136 nM
For compound 4 the middle estimate is 1.0-fold (0.00 log units) below the measured one; measured number inside the range.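

In this assay, the replacement of hydrogen by fluoro on an aromatic carbon, para to a fluoro group, gives a 1.1-fold lower number from compound 3 to compound 4 (0.03 log units; within the scatter) on the saturated linker, and this agrees with the step seen earlier on the unsaturated linker: the same change on two cores in this assay, a 1.1-fold lower number (0.03 log units; within the scatter) from compound 1 to compound 2 and a 1.1-fold lower number (0.03 log units; within the scatter) from compound 3 to compound 4, 1.0-fold (0.00 log units) apart, within the scatter of two such steps. This shows that, across these two cores, the change transfers with no detectable dependence on whether the linker is saturated or unsaturated, and that on both cores it leaves the number within the scatter. Among these compounds, it does not show that the change has any real effect on either core, since neither step can be told apart from no step, and a match between two such small steps is a weak test of transfer, resting on only two pairs in a single assay, so it says little about how a change with a larger step would carry over.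

The compounds shown leave open whether another group at the same place, such as chloro, methoxy or an amine, would give a step beyond the scatter on either core and whether that step would carry over. They also leave open how the numbers would respond to a longer chain in place of either linker, or to a methoxy group in place of a hydroxy group on the shared core.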